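Swapping the Isobutyl Chain for Ethylsulfanyl on the Carbonyl

The source may report more compounds than this note shows. Statements on the series, on what has been measured and on what is new or still open speak of the compounds shown alone.

Compound 1 `CC1=C(C(=O)CC(C)C)C(c2cccs2)NC(=O)N1` gives 18% in an assay on membranes from HeLa cells for displacement of a labelled ligand from adenosine receptor A3 (Homo sapiens), read by scintillation counting, with a stated time of 180 min, tested at 1 uM; a higher number here means more inhibition at the concentration tested (going by the name of the read-out), a lower number less inhibition.
Compound 2 `CC1=C(C(=O)CC(C)C)C(c2ccsc2)NC(=O)N1` gives 14% in this assay.

Among the measured compounds shown here, of the two numbers measured, compound 2 has the smaller one, but its only neighbour, compound 1, sits close by: the step of a number 4 percentage points lower from compound 1 to compound 2 (within the scatter) stays within the scatter, so the two compounds cannot be told apart. Compound 3 `CCSC(=O)C1=C(C)NC(=O)NC1c1ccsc1` keeps the shared core of compound 2 and differs in one place: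
ethylsulfanyl in place of isobutyl on a carbonyl carbon
For the measured compounds named here, the single measured step concerns the thiophene ring on a saturated ring carbon and says nothing about the group on the carbonyl carbon; no measured pair bears on this change. With nothing pointing either way, the expectation for compound 3 in this assay is a number near that of compound 2, a step of a number 1 percentage points higher from compound 2 to compound 3 (within the scatter) that is not expected to go beyond the scatter. Compound 3 is therefore estimated at 15%, with a range from 0% to 40%.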

Compound 3, a percentage reported as inhibition, at one concentration (the size of the read-out at that concentration, not a potency): 2%
For compound 3 the middle estimate is 13 percentage points above the measured one, within the range that was stated.
By their numbers in this assay, from the lowest: compound 3; then compounds 2 and 1 (each within the scatter of the next).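

Replacing isobutyl with ethylsulfanyl on the carbonyl carbon gives a number 12 percentage points lower from compound 2 to compound 3 (beyond the scatter) in this assay and so, unlike the change in the thiophene ring, produces a difference that can be read. The group on this carbonyl carbon therefore has a visible bearing on the read-out, and in this one pair the ethylsulfanyl group lowers the inhibition seen at the tested concentration. Nothing available explains why the number drops, and the sulfur cannot be separated from the change in the chain.

Still open, going by these compounds, is whether an ethoxy group or an amine on the same carbonyl carbon would stay near the value of the isobutyl compound or fall as well. Also open, on these data alone, is whether ethylsulfanyl would have the same effect with the thiophen-2-yl group of compound 1.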